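Cyano addition on two bicyclic cores: cytotoxicity notes

A few compounds are considered here, and "the series" means these few. Any claim that something is new, unique, unknown or untested is made for them only; others in the source may bear on it.

Compound 1 `O=C(O)[C@H]1C2CCC(CC2)[C@@H]1n1ccc2cnc(-c3c[nH]c4ncc(F)cc34)nc21` and compound 2 `N#Cc1cn([C@H]2C3CCC(CC3)[C@@H]2C(=O)O)c2nc(-c3c[nH]c4ncc(F)cc34)ncc12` share one core; compound 3 `O=C(O)[C@H]1C2CCC(CC2)[C@@H]1Nc1nc(-c2c[nH]c3ncc(F)cc23)nc2ccsc12` and compound 4 `N#Cc1csc2c(N[C@H]3C4CCC(CC4)[C@@H]3C(=O)O)nc(-c3c[nH]c4ncc(F)cc34)nc12` share another, and the difference between the two cores is not broken down here. In an ADME assay on MDCK cells (Canis lupus familiaris) for cytotoxicity, read by CCK-8 assay, with a stated time of 5 days (on this read-out higher numbers stand for lower toxicity in this test and lower numbers for higher toxicity in this test), compound 1 gives 4000 nM and compound 2 gives 5400 nM. The change between them, (cyano in place of hydrogen on an aromatic carbon), made a step of a 1.4-fold higher number from compound 1 to compound 2 (0.13 log units; within the scatter). Compound 3 gives 1500 nM in this assay. Compound 4 carries the same kind of change, (cyano in place of hydrogen on an aromatic carbon), though here the place is a five-membered aromatic ring with 1 sulfur, two ring bonds from the ring sulfur, rather than a ring with 1 nitrogen with two ring bonds from the ring atom that bears a large group. An expected step of a 1.3-fold higher number from compound 3 to compound 4 (0.10 log units; within the scatter) rests on the earlier one, because a 1.4-fold higher number from compound 1 to compound 2 (0.13 log units; within the scatter) stayed within the scatter. Compound 4 is accordingly estimated at 1900 nM, expected between 800 nM and 4500 nM.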

Compound 4, half-maximal cytotoxic concentration: 700 nM
The estimate for compound 4 lay 2.7-fold (0.43 log units) above the measured number; the measured number lies below the stated range.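

In this assay, cyano in place of hydrogen on an aromatic carbon gave a 2.1-fold lower number from compound 3 to compound 4 (0.33 log units; beyond the scatter), and the change did not carry over unchanged from one core to the other: the same change on two cores in this assay, a 1.4-fold higher number (0.13 log units; within the scatter) from compound 1 to compound 2 and a 2.1-fold lower number (0.33 log units; beyond the scatter) from compound 3 to compound 4, 2.9-fold (0.46 log units) apart, beyond the scatter of two such steps. The step seen on the core of compound 1 is therefore a poor guide to the step on the core of compound 3. With one pair per core, and the cyano on a different ring in each, this does not show whether the core or the place accounts for the gap, nor does it give a rule for the series.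

Open, as far as these compounds go, is whether a methyl group or an amine on the same aromatic carbon would separate the two cores in the same way. Also open, from the compounds shown here alone, is whether cyano on another carbon of either core would give a step of similar size.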